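This account rests on a few compounds, and the source may have more. Where it says the series, first, only, none or still open, it means among the compounds named here.

Working notes on the prolinamide series, step from compound 3 to compound 4.

The series is read in an assay on CHO cells for displacement of a labelled ligand from Orexin/Hypocretin receptor type 1 (Homo sapiens); a higher number here means a weaker inhibitor, a lower number a stronger inhibitor. Compound 1 `O=C(Nc1ccccc1-c1ccccc1)[C@@H]1CCCN1C(=O)CSc1nc2ccccc2[nH]1` gives 10 nM. Within the data shown here, compound 2 `Cn1c(SCC(=O)N2CCC[C@H]2C(=O)Nc2ccccc2-c2ccccc2)nc2ccccc21` gives 3 nM; the only step measured so far, a 3.3-fold lower number from compound 1 to compound 2 (0.52 log units; beyond the scatter), is methyl in place of hydrogen on an aromatic nitrogen and leaves the anilide part untouched. Among the measured compounds shown here, compound 3 `O=C(Nc1ccc(-c2ccccc2)cc1)[C@@H]1CCCN1C(=O)CSc1nc2ccccc2[nH]1` gives 2300 nM, the highest number of the three; compound 1 and compound 3 carry the same phenyl on the anilide ring at different positions, and their two values differ widely, though no step is computed for that pair.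

Compound 4 `O=C(Nc1ccccc1)[C@@H]1CCCN1C(=O)CSc1nc2ccccc2[nH]1` is the unmeasured member: hydrogen in place of phenyl on an aromatic carbon. For the measured compounds named here, no measured step touches the anilide substitution, so the one step on record, on the aromatic nitrogen, does not bear on this change and gives no guide to its size or direction. Only the values of compound 1 and compound 3 suggest that the anilide substitution matters strongly. On that basis compound 4 is expected to land between the two, with an estimated step of a 2.9-fold lower number from compound 3 to compound 4 (0.46 log units; beyond the scatter) in this assay. The estimate for compound 4 is 800 nM, within a range of 120 nM to 6000 nM.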

Compound 4, inhibition constant: 1400 nM
Compound 4: middle estimate off by 1.8-fold (0.24 log units), on the low side; measured number inside the range.
By their numbers in this assay, from the lowest: compound 2; then compound 1; then compounds 4 and 3 (each within the scatter of the next).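

Hydrogen and phenyl on the aromatic carbon para to a large group cannot be told apart in this assay: a 1.6-fold lower number from compound 3 to compound 4 (0.22 log units; within the scatter). The same exchange at the place phenyl occupies in compound 1 is far larger, a 140-fold higher number from compound 1 to compound 4 (2.15 log units; beyond the scatter), so across compound 1, compound 3 and compound 4 the contribution of phenyl depends on where it sits on the anilide ring, and only the placement in compound 1 separates from the unsubstituted anilide of compound 4. Nothing on hand accounts for this dependence on placement.

Open, as far as these compounds go, is how much of the step to compound 1 needs a whole phenyl ring: a methoxy group, a chlorine atom or an aminomethyl group at that same place would show whether a smaller substituent keeps the low number, and the same groups at the place para to a large group would show whether that place tolerates anything other than hydrogen and phenyl without a shift. Also open, from the compounds shown here alone, is whether methyl in place of hydrogen on the aromatic nitrogen carries the same step when the anilide is that of compound 4 or compound 3 rather than that of compound 1.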